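The compounds below may be only part of what the source reports. "The series", "measured", "known", "first", "only" and "open" are said of these compounds alone.

In a functional assay on MCF7 cells (Homo sapiens) for inhibition, read by MTT assay, with a stated time of 24 h (a higher number here means a weaker inhibitor, a lower number a stronger inhibitor), compound 1 `CCOC(=O)C1=Cc2ccccc2OC1(OCc1cc(-c2ccc(OC)cc2)no1)C(F)(F)F` gives only a limit, > 150000 nM. Compound 2 `CCOC(=O)C1=Cc2ccccc2OC1(OCc1cn(-c2ccccc2)nn1)C(F)(F)F` likewise reaches only a limit in this assay, > 150000 nM. For the measured compounds named here, compound 3 `COc1ccc(-c2cc(COC3(C(F)(F)F)Oc4ccccc4C=C3C(=O)O)on2)cc1` gives 35200 nM in this assay, the sole number among the three values shown. The other two values are the limit of > 150000 nM in this assay, at which 2 of the 3 values shown sit. Going by the values given here, the single measured step, an at least 4.2-fold lower number from compound 1 to compound 3 (0.62 log units; beyond the scatter), concerns the oxygen next to the carbonyl group and not the aryl substituent. Compound 4 `Cc1ccc(-c2cc(COC3(C(F)(F)F)Oc4ccccc4C=C3C(=O)O)on2)cc1` differs from compound 3 by methyl in place of methoxy on an aromatic carbon. No measured step touches that aromatic carbon, so nothing shown argues for a shift beyond the scatter in either direction. The expected step is a 1.0-fold lower number from compound 3 to compound 4 (0.00 log units; within the scatter), within the scatter. Compound 4 is therefore estimated at 35000 nM, between 12000 nM and 110000 nM.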

Compound 4, half-maximal inhibitory concentration: 30100 nM
For compound 4 the middle estimate is 1.2-fold (0.07 log units) above the measured one; the range from low to high includes it.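

For the compounds shown here, the first measured step on this aromatic carbon is a 1.2-fold lower number from compound 3 to compound 4 (0.07 log units; within the scatter) and it shows that, in this assay, 4-methoxyphenyl can give way to 4-methylphenyl without a shift beyond the scatter. The earlier compounds had shown a step only at the ethyl group, not on the aryl substituent. Nothing measured here offers a reason for this result.

Only methoxy and methyl are shown on this carbon, so the effect of an amine, a chlorine or a longer chain there remains open. Also open, from the compounds shown here alone, is whether this change would read the same with the ethyl group kept.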